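Shortening the chain of compound 2

The source may hold more compounds than are shown below. What is called first, only, known or untested is meant among the compounds shown, and "the series" means these compounds.

In a physicochemical assay for metabolic stability, at pH 8, in the presence of a further agent that is not named here (a lower number here means that the compound disappears faster, a higher number that the compound lasts longer), the measured compounds stand as follows
Compound 1 `Cc1cn([C@H]2CO[C@@H](COC(=O)C3CCCCC3)O2)c(=O)[nH]c1=O` gives 0.322 h
Compound 2 `CCCCCCCCCCCCCCCC(=O)OC[C@@H]1OC[C@H](n2cc(C)c(=O)[nH]c2=O)O1` gives 0.8 h

Of the two, compound 2 stands highest at 0.8 h in this assay and compound 1 lies beyond the scatter under it. Compound 3 `CCCCCCCC(=O)OC[C@@H]1OC[C@H](n2cc(C)c(=O)[nH]c2=O)O1` has not yet been measured. It differs from compound 2 by hydrogen in place of octyl on a saturated chain carbon, seven bonds along the chain from a carbonyl carbon in that hydrogen stands in place of octyl on a saturated chain carbon, seven bonds along the chain from a carbonyl carbon. Among the compounds with values here, no pair of measured compounds shows this change. Within the data shown here, the only guide is that compound 1 (0.322 h) lasts for a shorter time than compound 2. A modest downward step in this assay is therefore expected, near the edge of the scatter. The expected step is estimated as a 2.0-fold lower number from compound 2 to compound 3 (0.30 log units; within the scatter) in this reading. For compound 3 the estimated half-life is 0.4 h with an expected range from 0.15 h to 1 h in repeat measurements.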

Compound 3, half-life: 0.483 h
For compound 3 the middle estimate is 1.2-fold (0.08 log units) below the measured one; the range from low to high includes it.
By their numbers in this assay, from the lowest: compounds 1, 3 and 2 (each within the scatter of the next, the first and the last beyond it).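

Placing hydrogen where octyl stood on a saturated chain carbon, seven bonds along the chain from a carbonyl carbon, gives a 1.7-fold lower number from compound 2 to compound 3 (0.22 log units; within the scatter) in this assay, so this shortening produces no step clear of repeat measurements. Heptyl in place of cyclohexyl on a carbonyl carbon gives a 1.5-fold higher number from compound 1 to compound 3 (0.18 log units; within the scatter), so this open chain and this ring cannot be told apart here, even though compound 1 and compound 2 lie beyond the scatter of each other. Nothing at hand gives a reason for either step.

The compounds shown leave open whether a shorter chain, such as propyl or methyl, would remain within the scatter of compound 3. They also leave open how an amine or a phenyl group on the carbonyl carbon would behave in this assay.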